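The source may report more compounds than this note shows. Statements on the series, on what has been measured and on what is new or still open speak of the compounds shown alone.

The measured compounds and their values:

Compound 1, `Oc1ccc(/C=C/c2ccccc2O)cc1`: 21 ug/mL
Compound 2, `Nc1ccccc1/C=C/c1ccc(O)cc1`: 79 ug/mL
Compound 3, `COc1ccccc1/C=C/c1cccc(O)c1`: 24.3 ug/mL

All three were tested in a functional assay on MCF7 cells (Homo sapiens) for inhibition, read by MTT assay, with a stated time of 2 days; on this read-out lower numbers stand for stronger inhibition and higher numbers for weaker inhibition. Compound 1 and compound 2 differ in one place: amino in place of hydroxy on an aromatic carbon. That change gave a 3.8-fold higher number from compound 1 to compound 2 (0.58 log units; beyond the scatter), so the amino compound was the weaker inhibitor.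

Compound 3 carries a different core from compound 1; the difference between the two cores is not broken down here. In this assay compound 3 gives 24.3 ug/mL, and against compound 1 the two values lie within the scatter of each other, while compound 2 stands well apart from both.

Compound 4, `COc1ccccc1/C=C/c1cccc(N)c1`, has not yet been measured. It differs from compound 3 in one place: amino in place of hydroxy on an aromatic carbon. For the measured compounds named here, this is the same kind of change as the one from compound 1 to compound 2, though the surroundings are not identical: in compound 1 the hydroxy sits ortho to a group of 9 heavy atoms, whereas in compound 3 it sits meta to a large group.

Going by the values given here, with only one example of this change measured, the expectation is that the step from compound 3 to compound 4 will be of similar size, estimated as a 2.9-fold higher number from compound 3 to compound 4 (0.46 log units; beyond the scatter), because the single earlier step was a 3.8-fold higher number from compound 1 to compound 2 (0.58 log units; beyond the scatter). On that basis compound 4 is expected to give about 70 ug/mL in this assay, with a plausible range from 30 ug/mL to 160 ug/mL.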

Compound 4, half-maximal inhibitory concentration: 38.7 ug/mL
Compound 4: the middle estimate sits 1.8-fold (0.26 log units) above what was measured; the range from low to high includes it.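

Exchanging hydroxy for amino on the core of compound 3 gave a 1.6-fold higher number from compound 3 to compound 4 (0.20 log units; within the scatter) in this assay, so on this core the effect of the change cannot be told apart from the usual scatter, unlike the clear step seen on the core of compound 1. Even so, the two steps cannot be said to differ from each other, and these data give no ground for claiming that the change behaves differently on the two cores: the same change on two cores in this assay, a 3.8-fold higher number (0.58 log units; beyond the scatter) from compound 1 to compound 2 and a 1.6-fold higher number (0.20 log units; within the scatter) from compound 3 to compound 4, 2.4-fold (0.37 log units) apart, within the scatter of two such steps

This means that the earlier step is compatible with the new one, but it does not show that the two are equal, and a single pair on each core is too little to set a rule for the series, all the more as the surroundings of the change are not the same on the two cores.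

The compounds shown leave open whether the same comparison would hold on a third core, and how other groups in the same place, such as a methylamino group, a fluorine atom or a carboxylic acid, would read in this assay. They also leave open whether the amino-for-hydroxy change would give a similar picture on any other cell line.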